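A Methyl on the Amide Nitrogen: Expecting Little Change

The compounds below may be only part of what the source reports. "The series", "measured", "known", "first", "only" and "open" are said of these compounds alone.

Of the compounds shown here, three sharing one core have been tested in a functional assay on EC9706 cells (Homo sapiens) for cytotoxicity, read by MTT assay, with a stated time of 72 h; on this read-out lower numbers stand for stronger inhibition and higher numbers for weaker inhibition. Compound 1 `CCNC(=O)N1CCN(C(=S)SCc2cn(Cc3ccccc3F)nn2)CC1` gives 23700 nM. Compound 2 `CCN(C)C(=O)N1CCN(C(=S)SCc2cn(Cc3ccccc3F)nn2)CC1`, which carries a methyl in place of hydrogen on an amide-type nitrogen, gives 15600 nM; the step of a 1.5-fold lower number from compound 1 to compound 2 (0.18 log units; within the scatter) is too small to count. Compound 3 `CCNC(=O)N1CCN(C(=S)SCc2cn(Cc3ccc(F)cc3)nn2)CC1` gives 27800 nM, the top number of the three, although the step of a 1.2-fold higher number from compound 1 to compound 3 (0.07 log units; within the scatter) stays within the scatter, as does the gap between compound 3 and compound 2. Compound 4 `CCN(C)C(=O)N1CCN(C(=S)SCc2cn(Cc3ccc(F)cc3)nn2)CC1` has not yet been measured. It differs from compound 3 by methyl in place of hydrogen on an amide-type nitrogen. Among the compounds with values here, the only measured step of this kind is a 1.5-fold lower number from compound 1 to compound 2 (0.18 log units; within the scatter), made on the other fluorophenyl pattern, and it did not exceed the scatter. The expected step of a 1.5-fold lower number from compound 3 to compound 4 (0.19 log units; within the scatter) is therefore small, at most a modest move toward a lower number. Compound 4 is estimated at 18000 nM, within a range from 8000 nM to 40000 nM.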

Compound 4, half-maximal inhibitory concentration: 14300 nM
For compound 4 the middle estimate is 1.3-fold (0.10 log units) above the measured one; the range from low to high includes it.
By their numbers in this assay, from the lowest: compounds 4, 2, 1 and 3 (each within the scatter of the next).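

With compound 4, methyl in place of the amide hydrogen can be read on both fluorophenyl patterns in this assay. The step of a 1.9-fold lower number from compound 3 to compound 4 (0.29 log units; within the scatter) is again too small to count, so this change has not moved the number beyond the scatter on either pattern, and the two steps agree: the same change on two cores in this assay, a 1.5-fold lower number (0.18 log units; within the scatter) from compound 1 to compound 2 and a 1.9-fold lower number (0.29 log units; within the scatter) from compound 3 to compound 4, 1.3-fold (0.11 log units) apart, within the scatter of two such steps

The swap of 2-fluorophenyl for 4-fluorophenyl can now also be read with the methyl present, and the step of a 1.1-fold lower number from compound 2 to compound 4 (0.04 log units; within the scatter) is likewise too small to count, in agreement with the step without the methyl: the same change on two cores in this assay, a 1.2-fold higher number (0.07 log units; within the scatter) from compound 1 to compound 3 and a 1.1-fold lower number (0.04 log units; within the scatter) from compound 2 to compound 4, 1.3-fold (0.11 log units) apart, within the scatter of two such steps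

Still open, going by these compounds, is whether a propyl chain or a benzyl group on this amide nitrogen would shift the number beyond the scatter. The same question stands for a chlorine or a methoxy group in place of the fluorine.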